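Notes on a ring-carbon aryl swap in the series

The compounds below may be only part of what the source reports. "The series", "measured", "known", "first", "only" and "open" are said of these compounds alone.

The shared core is that of compound 1 `CC1=C(C(=O)Nc2ccc([N+](=O)[O-])cc2)C(c2ccc(Br)cc2)N=C(SCc2ccccc2)N1`. In a functional assay on the whole organism (artery, strain albino) with Rattus norvegicus as the target, with a stated time of 720 min, at a dose of 10 mg/kg by the oral route (on this read-out lower numbers stand for less inhibition and higher numbers for more inhibition at the one dose given (going by the name of the read-out)), compound 1 gives 21.1%, the second highest of the three numbers measured. Compound 2 `CC1=C(C(=O)Nc2ccc([N+](=O)[O-])cc2)C(c2ccc(Br)cc2)N=C(SCc2cccc(Cl)c2)N1` gives 2.6% in this assay, and compound 3 `CC1=C(C(=O)Nc2ccc([N+](=O)[O-])cc2)C(c2ccc(Br)cc2)N=C(SCc2ccc(Cl)cc2)N1` gives 29.4%. The measured steps all concern the aryl of the benzylsulfanyl group: a number 18.5 percentage points lower from compound 1 to compound 2 (beyond the scatter), a number 8.3 percentage points higher from compound 1 to compound 3 (within the scatter), and a number 26.8 percentage points higher from compound 2 to compound 3 (beyond the scatter).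

Compound 4 `CC1=C(C(=O)Nc2ccc([N+](=O)[O-])cc2)C(c2cccc([N+](=O)[O-])c2)N=C(SCc2ccccc2)N1` is not yet measured. It differs from compound 1 in 3-nitrophenyl in place of 4-bromophenyl on a saturated ring carbon, a change on a saturated ring carbon of the six-membered non-aromatic ring with 2 nitrogen. For the measured compounds named here, none of the measured steps touches that position; all three concern the benzylsulfanyl aryl, so none bears directly on this change. Going by the values given here, with no relevant step to lean on, the expectation is of no step beyond the scatter, and the estimated step of a number 1.1 percentage points lower from compound 1 to compound 4 (within the scatter) is set near zero with a wide range. Compound 4 is therefore expected to give about 20% in this assay, with a range from 3% to 42%.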

Compound 4, a percentage reported as inhibition, in the whole organism at one dose (the size of the read-out at that dose, not a potency): 17.5%
Compound 4: the middle estimate sits 2.5 percentage points above what was measured; low and high end bracket the measured number.
By their numbers in this assay, from the lowest: compound 2; then compounds 4, 1 and 3 (each within the scatter of the next, the first and the last beyond it).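

In this assay, for the compounds shown here, the swap at this saturated ring carbon gives a number 3.6 percentage points lower from compound 1 to compound 4 (within the scatter), so this is the first sign that the read-out can stay within the scatter when the aryl here changes, while the earlier steps spoke only of the aryl of the benzylsulfanyl group. The change is not a simple one: the entering 3-nitrophenyl differs from the leaving 4-bromophenyl in both the kind of substituent and its number on the phenyl, and it brings 9 heavy atoms in place of 7 and 2 hydrogen-bond acceptors in place of 0, so a step this small cannot show whether each of these differences is without effect or whether they offset one another. No measured evidence bears on why the number stays within the scatter.

On these data alone, it remains open whether 4-nitrophenyl or 3-bromophenyl at this carbon, which would separate the substituent from its number on the phenyl, or a group of another kind such as an aminophenyl, a carboxyphenyl or a cyclohexyl, would also stay within the scatter. As far as these compounds go, it is equally open whether the swap behaves the same way with the 3-chlorophenyl of compound 2 or the 4-chlorophenyl of compound 3 in the benzylsulfanyl group.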